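Aryl substituent swaps in a melanoma cell series

The source may report more compounds than this note shows. Statements on the series, on what has been measured and on what is new or still open speak of the compounds shown alone.

Measured so far:
compound 1 `CC(C)c1ccc(Nc2nc(SCc3cn(CC(=O)NC(=O)Nc4ccccn4)nn3)nc(-c3ccc(C(C)C)cc3)c2C#N)cc1`, 4380 nM
compound 2 `Cc1ccc(-c2nc(SCc3cn(CC(=O)NC(=O)Nc4ccccn4)nn3)nc(Nc3ccc(C(C)C)cc3)c2C#N)cc1`, 35 nM
compound 3 `CC(C)c1ccc(Nc2nc(SCc3cn(CC(=O)NC(=O)Nc4ccccn4)nn3)nc(-c3ccc(Cl)cc3)c2C#N)cc1`, 1590 nM

In a functional assay on B16-F10 cells (Mus musculus) for inhibition, read by MTT assay, with a stated time of 72 h (a higher number here means a weaker inhibitor, a lower number a stronger inhibitor), compound 1 gives 4380 nM. Compound 2 differs from compound 1 by methyl in place of isopropyl on an aromatic carbon, and the step is a 130-fold lower number from compound 1 to compound 2 (2.10 log units; beyond the scatter). Compound 3 differs from compound 1 by chloro in place of isopropyl on an aromatic carbon, with a 2.8-fold lower number from compound 1 to compound 3 (0.44 log units; beyond the scatter); against compound 2 it shows a 45-fold higher number from compound 2 to compound 3 (1.66 log units; beyond the scatter), leaving compound 3 second highest of the three numbers.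

Compound 4 `Cc1ccc(Nc2nc(SCc3cn(CC(=O)NC(=O)Nc4ccccn4)nn3)nc(-c3ccc(Cl)cc3)c2C#N)cc1` is not yet measured. It differs from compound 3 by methyl in place of isopropyl on an aromatic carbon, the same change as from compound 1 to compound 2, here read one bond further out as (4-isopropylphenyl)amino to (4-methylphenyl)amino rather than on the ring that bears the chloro in compound 3. For the measured compounds named here, since the only precedent for this change is on the other ring, a smaller step than the earlier one is expected: a 3.2-fold lower number from compound 3 to compound 4 (0.50 log units; beyond the scatter), resting on compound 3 at 1590 nM and on the direction set by compound 2 at 35 nM. Compound 4 is estimated at 500 nM, between 100 nM and 2500 nM.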

Compound 4, half-maximal inhibitory concentration: 1320 nM
The estimate for compound 4 lay 2.6-fold (0.42 log units) below the measured number; the measured number falls inside the stated range.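

In this assay, replacing isopropyl with methyl on the (4-isopropylphenyl)amino group gives a 1.2-fold lower number from compound 3 to compound 4 (0.08 log units; within the scatter), so this step does not repeat the large drop seen with compound 2. The change therefore does not carry over unchanged between these two matched pairs: the same change on two cores in this assay, a 130-fold lower number (2.10 log units; beyond the scatter) from compound 1 to compound 2 and a 1.2-fold lower number (0.08 log units; within the scatter) from compound 3 to compound 4, 100-fold (2.02 log units) apart, beyond the scatter of two such steps. This does not show what sets the two steps apart, since they differ both in the shared surroundings and in the group changed, 4-isopropylphenyl in compound 1 and (4-isopropylphenyl)amino in compound 3, and a single pair of each kind cannot separate those two differences.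

Open, as far as these compounds go, is what happens with methyl on both aryl groups, and whether ethyl or methoxy at the same place would follow compound 2 or compound 4. Also open, from the compounds shown here alone, is whether the low number for compound 2, 35 nM, extends to other cell lines.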